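Lengthening the Urea Side Chain of a Guanidine Agonist

A few compounds are considered here, and "the series" means these few. Any claim that something is new, unique, unknown or untested is made for them only; others in the source may bear on it.

Three compounds share one core and differ only in the chain attached to the urea nitrogen. In a functional assay on membranes from Sf9 cells for agonist activity at histamine H2 receptor (Homo sapiens), read by scintillation counting and GTPgammaS binding, with a stated time of 90 min (on this read-out higher numbers stand for an effect only at larger amounts of compound and lower numbers for an effect already at smaller amounts), compound 1 `Cc1nc(N)sc1CCCN/C(N)=N/C(=O)NCC(C)CCc1ccccc1` gives 29.5 nM, compound 2 `CCCNC(=O)/N=C(\N)NCCCc1sc(N)nc1C` gives 178 nM, and compound 3 `N/C(=N\C(=O)NCc1ccccc1)NC1CCc2nc(N)sc2C1` gives 214 nM. Compound 2 sits second highest of the three; its gap to compound 3 is within the scatter, while compound 1 lies clearly lower. Among the measured compounds shown here, the one single-point change measured is a 6.0-fold higher number from compound 1 to compound 2 (0.78 log units; beyond the scatter), so the longer chain went with the lower number. Compound 4 `CCCCCCNC(=O)/N=C(\N)NCCCc1sc(N)nc1C` carries propyl in place of hydrogen on a saturated chain carbon, three bonds along the chain from an amide-type nitrogen. Because a 6.0-fold higher number from compound 1 to compound 2 (0.78 log units; beyond the scatter) favored the longer chain, a lower number is expected for compound 4, with a 3.0-fold lower number from compound 2 to compound 4 (0.47 log units; beyond the scatter). Compound 4 is therefore estimated at 60 nM, within a range from 20 nM to 180 nM.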

Compound 4, half-maximal effective concentration: 38.9 nM
For compound 4 the middle estimate is 1.5-fold (0.19 log units) above the measured one; measured number inside the range.
By their numbers in this assay, from the lowest: compounds 1 and 4 (each within the scatter of the next); then compounds 2 and 3 (each within the scatter of the next).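

In this assay, the step from hydrogen to propyl gives a 4.6-fold lower number from compound 2 to compound 4 (0.66 log units; beyond the scatter). The earlier step placed phenethyl at a different chain carbon, whereas this one shows that a lower number at this position needs no ring: the group added here is a plain propyl, which extends the chain to hexyl. Open questions remain about whether a longer chain would lower the number further, and whether an amine or a carboxylic acid at the chain end would keep this gain. No measurement shown here explains the change.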